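Changing the aryl group on an amide nitrogen

The compounds below may be only part of what the source reports. "The series", "measured", "known", "first", "only" and "open" are said of these compounds alone.

Compound 1 `CCOC(=O)C1=Cc2ccccc2OC1(OCc1cn(CC(=O)Nc2ccc(C)cc2)nn1)C(F)(F)F` gives > 150000 nM in a functional assay on MCF7 cells (Homo sapiens) for inhibition, read by MTT assay, with a stated time of 24 h; on this read-out lower numbers stand for stronger inhibition and higher numbers for weaker inhibition; this is a limit of the assay, not a number.
Compound 2 `Cc1ccc(-c2cc(COC3(C(F)(F)F)Oc4ccccc4C=C3C(=O)O)on2)cc1` gives 30100 nM in this assay.
Compound 3 `CCOC(=O)C1=Cc2ccccc2OC1(OCc1cc(-c2ccc(Br)cc2)no1)C(F)(F)F` gives > 150000 nM in this assay, again a limit rather than a number.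

Compound 1 thus sits at the limit of > 150000 nM in this assay, at which 2 of the 3 values shown sit. Compound 4 `CCOC(=O)C1=Cc2ccccc2OC1(OCc1cn(CC(=O)Nc2cccc(F)c2)nn1)C(F)(F)F` differs from compound 1 in one place: 3-fluorophenyl in place of 4-methylphenyl on an amide-type nitrogen. Among the compounds with values here, no directly comparable pair has been measured, so the size of this step is unknown, and nothing among the three measured compounds suggests it would move the value beyond the usual scatter. In this assay the step from compound 1 to compound 4 is expected to be small, a number no higher from compound 1 to compound 4 (the limit leaves the size open). Compound 4 is expected at about 150000 nM, between 60000 nM and 400000 nM, most likely reported again as a limit.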

Compound 4, half-maximal inhibitory concentration: > 150000 nM
Compound 4: only a limit was reported; the forecaster's own chance of this, stated with the estimate: 75%; the middle value lies on the limit itself.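

Compound 1 and compound 4 are both reported only as limits in this assay, so the step between them cannot be read. On these data alone, whether 3-fluorophenyl and 4-methylphenyl on the amide-type nitrogen differ in strength of inhibition remains open.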